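Swapping the Aryl Group on a Bromophenyl Enone Series

The compounds below may be only part of what the source reports. "The series", "measured", "known", "first", "only" and "open" are said of these compounds alone.

Compound 3 `Cc1ccc(S/C(=C/c2ccc(N(C)C)cc2)C(=O)c2ccc(Br)cc2)cc1` and compound 1 `COc1ccccc1/C=C(/Sc1ccc(C)cc1)C(=O)c1ccc(Br)cc1` share a core and differ by 2-methoxyphenyl in place of 4-(dimethylamino)phenyl on a double-bonded chain carbon bound to a double-bonded chain carbon. In a functional assay on DU-145 cells (Homo sapiens) for inhibition, read by trypan blue exclusion, with a stated time of 96 h (on this read-out higher numbers stand for weaker inhibition of growth and lower numbers for stronger inhibition of growth), compound 3 reaches only a limit of the assay, > 100000 nM. Compound 1 gives 9000 nM in this assay, so the change brings an at least 11-fold lower number from compound 3 to compound 1 (1.04 log units; beyond the scatter), a step anchored by the limit of > 100000 nM in this assay, at which 1 of the 3 values shown sits. Compound 2 `CN(C)c1ccc(/C=C(\C(=O)c2ccc(Br)cc2)S(=O)(=O)Cc2ccc(F)cc2)cc1` carries a different core; how its core differs from that of compound 3 is not broken down here. In this assay compound 2 gives 50000 nM. Compound 4 `COc1ccccc1/C=C(\C(=O)c1ccc(Br)cc1)S(=O)(=O)Cc1ccc(F)cc1` is compound 2 with the same change, (2-methoxyphenyl in place of 4-(dimethylamino)phenyl on a double-bonded chain carbon bound to a double-bonded chain carbon). Since the earlier pair gave an at least 11-fold lower number from compound 3 to compound 1 (1.04 log units; beyond the scatter), the step is expected to be about a 13-fold lower number from compound 2 to compound 4 (1.10 log units; beyond the scatter), with the limit in compound 3 leaving the true size open. Compound 4 is therefore estimated at 4000 nM, between 800 nM and 20000 nM.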

Compound 4, concentration for 50% growth inhibition: 25000 nM
For compound 4 the middle estimate is 6.3-fold (0.80 log units) below the measured one; the measured number lies above the stated range.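

In this assay, 2-methoxyphenyl in place of 4-(dimethylamino)phenyl gives a 2.0-fold lower number from compound 2 to compound 4 (0.30 log units; within the scatter). The change therefore did not carry over in size from one core to the other: the same change on two cores in this assay, an at least 11-fold lower number (1.04 log units; beyond the scatter) from compound 3 to compound 1 and a 2.0-fold lower number (0.30 log units; within the scatter) from compound 2 to compound 4, at least 5.5-fold (0.74 log units) apart, beyond the scatter of two such steps. On these data alone, two cores do not show how the change would behave on any other core, and the size of the earlier step remains open: the limit of > 100000 nM in this assay, at which 1 of the 4 values shown sits.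

As far as these compounds go, whether a plain phenyl or a 4-hydroxyphenyl in the same place would behave alike on both cores remains open. The compounds shown also leave open which part of the difference between the two cores sets the size of the step.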